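Terminal aryl variation on the shared core

A few compounds are considered here, and "the series" means these few. Any claim that something is new, unique, unknown or untested is made for them only; others in the source may bear on it.

Measured so far:
compound 1 `CCC(C)(C)Cc1c[nH]c(CCc2ccc(-c3cccc(C)n3)cc2)n1` — 6.3 nM
compound 2 `CCC(C)(C)Cc1c[nH]c(CCc2ccc(-c3cccc(C#N)n3)cc2)n1` — 140 nM
compound 3 `CCC(C)(C)Cc1c[nH]c(CCc2ccc(-c3cnsc3)cc2)n1` — 10 nM

All numbers come from an in vitro assay on CHO cells for displacement of a labelled ligand from Bombesin receptor subtype-3 (Homo sapiens), read by scintillation counting, with a stated time of 2 h; on this read-out lower numbers stand for stronger inhibition and higher numbers for weaker inhibition. Compound 3 holds the second highest number of the three. Its nearest neighbour is compound 1, the ring swap giving a 1.6-fold higher number from compound 1 to compound 3 (0.20 log units; within the scatter). The furthest is compound 2, where the change gives a 14-fold lower number from compound 2 to compound 3 (1.15 log units; beyond the scatter).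

Compound 4 `CCC(C)(C)Cc1c[nH]c(CCc2ccc(-c3cccnc3C(=O)O)cc2)n1` is not yet measured. The change from compound 3 is 2-carboxypyridin-3-yl in place of 1,2-thiazol-4-yl on an aromatic carbon. For the measured compounds named here, no measured pair carries this exact change. Two kinds of step bear on it. Swapping one five- or six-membered aryl for another left the number essentially in place, as shown by a 1.6-fold higher number from compound 1 to compound 3 (0.20 log units; within the scatter). Placing a cyano in place of a methyl on the pyridine ring, however, gave a 22-fold higher number from compound 1 to compound 2 (1.35 log units; beyond the scatter), a large shift toward weaker inhibition. Compound 4 both swaps the ring and introduces a carboxylic acid group, a larger alteration than either measured step, so a shift toward a higher number beyond the scatter is expected, of roughly a 15-fold higher number from compound 3 to compound 4 (1.18 log units; beyond the scatter). Compound 4 is therefore estimated at 150 nM, with a range from 30 nM to 1000 nM.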

Compound 4, half-maximal inhibitory concentration: 560 nM
Estimate against measurement, compound 4: 3.7-fold (0.57 log units) below; the measured number falls inside the stated range.
By their numbers in this assay, from the lowest: compounds 1 and 3 (each within the scatter of the next); then compound 2; then compound 4.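

In this assay, the aromatic carbon para to a large group does not take every ring exchange alike: the swap between compound 1 and compound 3 stayed within the scatter, whereas 2-carboxypyridin-3-yl in place of 1,2-thiazol-4-yl gives a 56-fold higher number from compound 3 to compound 4 (1.75 log units; beyond the scatter) and stands as a large loss. The same group also compares poorly with the methylpyridine, with an 89-fold higher number from compound 1 to compound 4 (1.95 log units; beyond the scatter), and goes further than the cyanopyridine, with a modest 4.0-fold higher number from compound 2 to compound 4 (0.60 log units; beyond the scatter), so the large loss seen with the cyano change is not the upper end of what this position can show. All three steps lie beyond the scatter, which makes compound 4 the weakest of the four, and nothing measured on these compounds accounts for the size of these steps.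

Compound 4 differs from compound 3 in both the ring and the acid group, so the compounds shown leave open how much of the step belongs to each. An unsubstituted pyridin-3-yl, or a methyl ester or primary amide in place of the carboxylic acid, would separate these two parts.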